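The source may report more compounds than this note shows. Statements on the series, on what has been measured and on what is new or still open speak of the compounds shown alone.

Compound 1 `COc1ccccc1OCCNc1cnn(Cc2ccc(OC)c(OCC3CC3)c2)c(=O)c1Cl`: > 100000 nM
Compound 2 `COc1ccccc1OCCNc1ccc(=O)n(Cc2ccc(OC)c(OC3CCCC3)c2)n1`: 28000 nM
Compound 3 `COc1ccccc1OCCNc1ccc(=O)n(Cc2ccc(OC(F)F)c(OC3CCCC3)c2)n1`: 9100 nM

These results come from a functional assay on K562 cells (Homo sapiens) for antiproliferative activity, read by MTT assay, with a stated time of 48 h; on this read-out lower numbers stand for stronger inhibition of growth and higher numbers for weaker inhibition of growth. The entry for compound 1, > 100000 nM, is a limit and not a number. Of the two true numbers, compound 2 has the higher, 28000 nM, which marks it as the weaker growth inhibitor of the pair.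

Compound 4 `COc1ccccc1OCCNc1ccc(=O)n(Cc2ccc(OC)c(OCC3CC3)c2)n1` keeps the core of compound 2 and changes one group: cyclopropylmethyl in place of cyclopentyl on an oxygen on an aromatic ring. Among the compounds with values here, the only measured step, a 3.1-fold lower number from compound 2 to compound 3 (0.49 log units; beyond the scatter), was modest and involved a different group, difluoromethyl in place of methyl, so it offers only loose guidance. No change beyond the scatter is therefore expected in this assay. The expected step is a 1.3-fold higher number from compound 2 to compound 4 (0.10 log units; within the scatter). Compound 4 is estimated at 35000 nM, with an expected range of 12000 nM to 100000 nM.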

Compound 4, concentration for 50% growth inhibition: 16600 nM
Compound 4: middle estimate off by 2.1-fold (0.32 log units), on the high side; the measured number falls inside the stated range.
By their numbers in this assay, from the lowest: compounds 3, 4 and 2 (each within the scatter of the next, the first and the last beyond it). At a limit, above all of these: compound 1.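

In this assay, cyclopropylmethyl in place of cyclopentyl on an oxygen on an aromatic ring gives a 1.7-fold lower number from compound 2 to compound 4 (0.23 log units; within the scatter) and so no change that can be told from repeat-measurement noise. At this position, therefore, the two carbon-only ring groups read alike, even though their rings differ in size. Nothing measured here explains this result.

Still open, going by these compounds, is whether an open chain such as isobutyl, or a ring carrying an amine, would read the same here. Also open, on these data alone, is whether this swap behaves alike alongside the difluoromethyl group of compound 3.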